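The compounds below may be only part of what the source reports. "The series", "measured", "known", "first", "only" and "open" are said of these compounds alone.

Measured so far: compound 1 `CC(C)(C)CCC1([C@H](O)/C=C/[C@H]2COC(=O)N2CCSc2nc(C(=O)O)cs2)CCC1` gives 6.7 nM in an assay on isolated protein for agonist activity at prostaglandin E2 receptor EP3 subtype (Homo sapiens); on this read-out higher numbers stand for an effect only at larger amounts of compound and lower numbers for an effect already at smaller amounts; compound 2 `CCOCCC1([C@H](O)/C=C/[C@H]2COC(=O)N2CCSc2nc(C(=O)O)cs2)CCC1` gives 2610 nM.

Compound 2 has the highest number of the two; the only step shown, a 390-fold higher number from compound 1 to compound 2 (2.59 log units; beyond the scatter), separates it from compound 1. Compound 3 `COCCCC1([C@H](O)/C=C/[C@H]2COC(=O)N2CCSc2nc(C(=O)O)cs2)CCC1` is the next isomer: methoxymethyl in place of ethoxy on a saturated chain carbon, two bonds along the chain from a saturated ring carbon. No measured step covers a shift of the oxygen along the chain; the one step shown concerns ethoxy in place of tert-butyl and does not transfer. A step of no clear direction, likely within the scatter, is expected for a 1.3-fold lower number from compound 2 to compound 3 (0.12 log units; within the scatter). Compound 3 is estimated at 2000 nM, with a range of 500 nM to 8000 nM.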

Compound 3, half-maximal effective concentration: 25 nM
Estimate against measurement, compound 3: 80-fold (1.90 log units) above; measured number below the stated range.
By their numbers in this assay, from the lowest: compound 1; then compound 3; then compound 2.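

In this assay, the two isomers differ only in how the same atoms are joined, and 2-ethoxyethyl to 3-methoxypropyl gives a 100-fold lower number from compound 2 to compound 3 (2.02 log units; beyond the scatter), so this position separates ether isomers widely. Methoxymethyl in place of tert-butyl gives a 3.7-fold higher number from compound 1 to compound 3 (0.57 log units; beyond the scatter), so the large loss seen for compound 2 does not hold for every ether chain here. No evidence on the origin of the gap between the isomers is available. Still open, going by these compounds, is how a 4-methoxybutyl chain, or an amine or a hydroxyl group in place of the ether oxygen, would read.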